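The source may hold more compounds than are shown below. What is called first, only, known or untested is meant among the compounds shown, and "the series" means these compounds.

Three compounds of the series have numbers in hand. Compound 1 `CC(=O)OC[C@H]1O[C@@H](n2cc(Cn3cc([N+](=O)[O-])c4ccccc43)nn2)[C@H](OC(C)=O)[C@@H](OC(C)=O)[C@@H]1OC(C)=O` gives 93200 nM in a functional assay on A549 cells (Homo sapiens) for cytotoxicity, read by sulforhodamine B assay, with a stated time of 48 h; on this read-out lower numbers stand for stronger inhibition and higher numbers for weaker inhibition. Compound 2 `CC(=O)OC[C@H]1O[C@@H](n2cc(CN3C(=O)/C(=C\c4ccccc4)c4ccccc43)nn2)[C@H](OC(C)=O)[C@@H](OC(C)=O)[C@@H]1OC(C)=O` gives 17900 nM in this assay, the lowest of the three numbers, and compound 3 `CC(=O)OC[C@H]1O[C@@H](n2cc(CN3C(=O)/C(=C/c4ccccc4)c4ccccc43)nn2)[C@H](OC(C)=O)[C@@H](OC(C)=O)[C@@H]1OC(C)=O` gives 20600 nM. The step of a 1.2-fold higher number from compound 2 to compound 3 (0.06 log units; within the scatter) lies within the scatter; since the fact that compounds 2 and 3 differ only in the configuration as drawn is the only point of difference, the drawn geometry of the exocyclic double bond shows no effect here. Within the data shown here, compound 1 sits furthest from compound 2, beyond the scatter, but no single-point change links them, so their two values show only that the cores differ.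

Compound 4 `CC(=O)OC[C@H]1O[C@@H](n2cc(CN3C(=O)/C(=C\c4ccc(N(C)C)cc4)c4ccccc43)nn2)[C@H](OC(C)=O)[C@@H](OC(C)=O)[C@@H]1OC(C)=O` is the next compound for this assay. It is built from compound 2 by dimethylamino in place of hydrogen on an aromatic carbon. Among the measured compounds shown here, no measured step touches this aromatic ring: the only step in hand, from compound 2 to compound 3, concerns configuration alone and says nothing about a substituent on the shared core. For the measured compounds named here, with no precedent, the expectation for compound 4 rests on compound 2 alone, and the step of a 1.2-fold lower number from compound 2 to compound 4 (0.08 log units; within the scatter) is expected to stay within or near the scatter. Compound 4 is therefore estimated at 15000 nM, with a range from 5000 nM to 40000 nM.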

Compound 4, half-maximal inhibitory concentration: 17700 nM
Compound 4: middle estimate off by 1.2-fold (0.07 log units), on the low side; the measured number falls inside the stated range.
By their numbers in this assay, from the lowest: compounds 4, 2 and 3 (each within the scatter of the next); then compound 1.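

In this assay, dimethylamino in place of hydrogen on an aromatic carbon, para to a large group, reads as a 1.0-fold lower number from compound 2 to compound 4 (0.00 log units; within the scatter) and so leaves the number where it stood. Among these compounds, this is the first measured step on this six-membered aromatic ring, since the earlier step between compounds 2 and 3 concerned configuration alone. It shows that, on the shared core, phenyl to 4-(dimethylamino)phenyl, an entering group of 3 heavy atoms, can be made at this place without a step beyond the scatter, and nothing in hand gives a measured property that bears on this result.

Whether the same holds for other kinds of group at this place, such as a carboxylic acid, a nitrile or a longer alkoxy chain, stays open, so the compounds shown do not say whether any substituent here can move the number beyond the scatter. Also open, as far as these compounds go, is whether dimethylamino would read the same on the other drawn double-bond geometry of compound 3, or on the core of compound 1.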